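Notes on the aryl group borne by the ring nitrogen

The source may report more compounds than this note shows. Statements on the series, on what has been measured and on what is new or still open speak of the compounds shown alone.

Two compounds of the series have been run in a functional assay on PC-12 cells (Rattus norvegicus) for cytotoxicity, read by MTT assay, with stated times of 2 h and 24 h, tested at 1 uM; on this read-out lower numbers stand for a weaker effect and higher numbers for a stronger effect at the one concentration tested. Compound 1 `Oc1cc(C(F)(F)F)ccc1-c1nc(-c2ccccc2O)n(-c2ccc(Cl)cc2)n1` gives 68% in this assay. Compound 2 `COc1ccc(-n2nc(-c3ccc(C(F)(F)F)cc3O)nc2-c2ccccc2O)cc1` gives 69% in this assay; compound 2 stands highest of the two numbers shown, with compound 1 its nearest, though the two lie within the scatter of each other. For the measured compounds named here, the only measured step, a number 1 percentage points higher from compound 1 to compound 2 (within the scatter), accordingly shows no effect beyond the scatter.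

Compound 3 `Oc1cc(C(F)(F)F)ccc1-c1nc(-c2ccccc2O)n(-c2cccc(C(F)(F)F)c2)n1` has not yet been measured. It differs from compound 2 as follows: 3-(trifluoromethyl)phenyl in place of 4-methoxyphenyl on an aromatic nitrogen. Going by the values given here, the one step that bears on this change is a number 1 percentage points higher from compound 1 to compound 2 (within the scatter): it also alters the substituent of the aryl ring on the aromatic nitrogen, and it stays within the scatter. Among the compounds with values here, no measured pair covers the larger swap of 4-methoxyphenyl for 3-(trifluoromethyl)phenyl, so the expectation rests on that single flat step. In this assay compound 3 is therefore expected to give 68%, with a range from 56% to 80%. The expected step is a number 1 percentage points lower from compound 2 to compound 3 (within the scatter), that is, nothing beyond the scatter.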

Compound 3, a percentage reported as activity, at one concentration (the size of the read-out at that concentration, not a potency): 71.5%
Estimate against measurement, compound 3: 3.5 percentage points below; low and high end bracket the measured number.
By their numbers in this assay, from the lowest: compounds 1, 2 and 3 (each within the scatter of the next).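

The wider exchange on the aromatic nitrogen, which changes the substituent and also where it sits on the aryl ring, leaves this assay without a change beyond the scatter: a number 2.5 percentage points higher from compound 2 to compound 3 (within the scatter), and a number 3.5 percentage points higher from compound 1 to compound 3 (within the scatter). The earlier pair covered only a swap between 4-chlorophenyl and 4-methoxyphenyl, whereas 3-(trifluoromethyl)phenyl shows that this position accepts a different substituent at a different ring place, and the read-out at the one concentration tested does not separate the three aryl groups. No measurement at hand accounts for this flat result.

Still open, from the compounds shown here alone, is whether any group on this nitrogen moves the read-out beyond the scatter, for instance an aryl ring carrying an amine or a carboxylic acid, or a longer alkyl chain in place of the aryl ring altogether. Also open, going by these compounds, is whether the three compounds stay together at other concentrations, since a single-concentration read-out gives no potency and the agreement seen here may not extend beyond that one test condition.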